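A few compounds are considered here, and "the series" means these few. Any claim that something is new, unique, unknown or untested is made for them only; others in the source may bear on it.

Measured compounds:
compound 1, `COc1ccc(-c2nc(C(=O)/C=C\Nc3ccc4[nH]ccc4c3)c3ccccn23)cc1`: 4800 nM
compound 2, `COc1ccc(-c2nc(C(=O)/C=C\Nc3ccc(Cl)cc3)c3ccccn23)cc1`: "not determined" (no result reported)

Among the compounds with values here, in a functional assay on A549 cells (Homo sapiens) for cytotoxicity, read by MTT assay, with a stated time of 48 h (on this read-out higher numbers stand for weaker inhibition and lower numbers for stronger inhibition), compound 1 gives 4800 nM and is the only compound of the series with a number; compound 2 has no result there. Compound 3, `O=C(/C=C\Nc1ccc2[nH]ccc2c1)c1nc(-c2ccc(C(F)(F)F)cc2)n2ccccc12`, is not yet measured. From compound 1 to compound 3 the change is trifluoromethyl in place of methoxy on an aromatic carbon. Within the data shown here, no step between measured compounds is available to anchor this change, so the expected shift a 1.2-fold lower number from compound 1 to compound 3 (0.08 log units; within the scatter) is small, not clearly beyond the usual scatter, in either direction. Compound 3 is expected to give about 4000 nM, within 1500 nM to 12000 nM.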

Compound 3, half-maximal inhibitory concentration: 5190 nM
Compound 3: middle estimate off by 1.3-fold (0.11 log units), on the low side; measured number inside the range.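

In this assay, trifluoromethyl in place of methoxy on an aromatic carbon, para to a large group, gives a 1.1-fold higher number from compound 1 to compound 3 (0.03 log units; within the scatter). Within the data shown here, this is the first step read at this position, and on this read-out the two groups cannot be told apart. Nothing shown accounts for this result.

From the compounds shown here alone, whether an amine or a carboxylic acid at the same position would depart from this level remains open. The group in which compound 2 differs from compound 1 also stays unread, with no number for compound 2 in this assay.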